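From Amide to Dimethylamide on an Adenosine Deaminase Inhibitor

The source may hold more compounds than are shown below. What is called first, only, known or untested is meant among the compounds shown, and "the series" means these compounds.

Of the compounds shown here, two sharing one core have so far been measured in an assay on isolated protein for inhibition of adenosine deaminase (Bos taurus), with a stated time of 5 min; on this read-out higher numbers stand for weaker inhibition and lower numbers for stronger inhibition. Compound 1 `C[C@H](O)[C@@H](CCc1cccc(-c2nccs2)c1)n1cnc2c(N)ncnc21` gives 2.6 nM in this assay. Compound 2 `C[C@H](O)[C@@H](CCc1cccc(C(N)=O)c1)n1cnc2c(N)ncnc21`, in which a carbamoyl group replaces the thiazolyl group on an aromatic carbon, gives 2.9 nM. The step of a 1.1-fold higher number from compound 1 to compound 2 (0.05 log units; within the scatter) shows that this exchange leaves the read-out essentially unchanged. Within the data shown here, compound 2 therefore sits within the scatter of compound 1, the only other measured number, so neither can be called the more or less potent of the pair.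

Compound 3 `C[C@H](O)[C@@H](CCc1cccc(C(=O)N(C)C)c1)n1cnc2c(N)ncnc21` differs from compound 2 by dimethylamino in place of amino on a carbonyl carbon. Among the measured compounds shown here, the single measured step, the exchange of the whole aromatic substituent from compound 1 to compound 2, altered the group on the same aromatic carbon and proved within the scatter, but no measured step tests the loss of the hydrogen-bond donor itself. The expectation for compound 3 is accordingly a small shift in this assay, if any, estimated as a 1.6-fold higher number from compound 2 to compound 3 (0.19 log units; within the scatter). Compound 3 is expected to give about 4.5 nM, within a range from 1.5 nM to 15 nM.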

Compound 3, inhibition constant: 1.8 nM
For compound 3 the middle estimate is 2.5-fold (0.40 log units) above the measured one, and the stated range covers the measured number.
By their numbers in this assay, from the lowest: compounds 3, 1 and 2 (each within the scatter of the next).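

In this assay, the exchange of dimethylamino for amino on a carbonyl carbon gives a 1.6-fold lower number from compound 2 to compound 3 (0.21 log units; within the scatter) and so takes the count of hydrogen-bond donors in this group from 1 to 0 and adds 2 carbons without a shift beyond the scatter. Together with a 1.4-fold lower number from compound 1 to compound 3 (0.16 log units; within the scatter) this means that 1,3-thiazol-2-yl, carbamoyl and dimethylcarbamoyl on this aromatic carbon all give numbers within the scatter of one another, so the three very different groups cannot be told apart by this read-out. No measurement is available that would explain why the read-out stays so flat across these groups.

The three compounds leave open whether any group on this aromatic carbon would move the number beyond the scatter, for instance a carboxylic acid, an aminomethyl group or a longer chain such as a diethylcarbamoyl group. They also leave open whether this flat picture would hold in a setting other than the isolated protein, such as in cells.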